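The compounds below may be only part of what the source reports. "The series", "measured", "known", "first", "only" and "open" are said of these compounds alone.

Measured in a functional assay on HT-1080 cells (Homo sapiens) for cytotoxicity, read by MTT assay, with a stated time of 72 h; a lower number here means a stronger inhibitor, a higher number a weaker inhibitor:
- compound 1 `COc1ccc(/C=C2\CCC/C(=C\c3ccc(Cl)cc3)C2=O)cc1OC`: 4800 nM
- compound 2 `COc1ccccc1/C=C1\CCC/C(=C\c2ccc(OC)c(OC)c2)C1=O`: 8100 nM
- compound 3 `COc1ccc(/C=C2\CCC/C(=C\c3ccc(Cl)c(Cl)c3)C2=O)cc1OC`: 3100 nM

At 3100 nM, compound 3 cannot be separated from compound 1, as shown by a 1.5-fold lower number from compound 1 to compound 3 (0.19 log units; within the scatter). It does stand apart from compound 2, as shown by a 2.6-fold lower number from compound 2 to compound 3 (0.42 log units; beyond the scatter).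

Next in the series is compound 4 `COc1cc(/C=C2\CCC/C(=C\c3ccc(OC)c(OC)c3)C2=O)ccc1O`, which has not yet been measured. The change is 4-hydroxy-3-methoxyphenyl in place of 3,4-dichlorophenyl on a double-bonded chain carbon bound to a double-bonded ring carbon: 4-hydroxy-3-methoxyphenyl in place of 3,4-dichlorophenyl, on a double-bonded chain carbon bound to a double-bonded ring carbon. The rest of the structure stays as in compound 3.

The closest evidence is the exchange at this same place between compound 2 and compound 3, a 2.6-fold lower number from compound 2 to compound 3 (0.42 log units; beyond the scatter), which is modest and has 3,4-dichlorophenyl as the entering group. Removing that group in compound 4 therefore points towards a higher number. The exchange a 1.7-fold higher number from compound 1 to compound 2 (0.23 log units; within the scatter) leans the same way but stays within the scatter. Among the compounds with values here, no measured compound carries a hydroxy group, so this direction remains tentative.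

In this assay, the expected change is small and upward, and it is not expected to clearly exceed the scatter. The estimated step is a 1.8-fold higher number from compound 3 to compound 4 (0.25 log units; within the scatter). For compound 4 the estimate is 5500 nM, with an expected range of 2000 nM to 14000 nM.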

Compound 4, half-maximal inhibitory concentration: 4600 nM
For compound 4 the middle estimate is 1.2-fold (0.08 log units) above the measured one; measured number inside the range.
By their numbers in this assay, from the lowest: compounds 3, 4, 1 and 2 (each within the scatter of the next, the first and the last beyond it).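

In this assay, 4-hydroxy-3-methoxyphenyl, the only group shown with a hydroxy group on a double-bonded chain carbon bound to a double-bonded ring carbon, cannot be separated from 3,4-dichlorophenyl (a 1.5-fold higher number from compound 3 to compound 4 (0.17 log units; within the scatter)), from 2-methoxyphenyl (a 1.8-fold lower number from compound 2 to compound 4 (0.25 log units; within the scatter)) or from 4-chlorophenyl (a 1.0-fold lower number from compound 1 to compound 4 (0.02 log units; within the scatter)). Within the data shown here, the place therefore accepts a group with a hydrogen-bond donor and hydrogen-bond acceptors in exchange for one with neither and with both chlorine atoms gone, without a step beyond the scatter, and the only exchange at this place that exceeds the scatter remains the one between the other two groups (a 2.6-fold lower number from compound 2 to compound 3 (0.42 log units; beyond the scatter)). Nothing measured here accounts for this tolerance.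

The compounds shown leave open whether the hydroxy group and the methoxy group of the entering group contribute separately, or whether their contributions merely cancel in this cell read-out. They also leave open whether a group of another kind at this place, such as an amine or a carboxylic acid, would give a step beyond the scatter in this assay.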